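Chloro in place of hydrogen on the purine core

The compounds below may be only part of what the source reports. "The series", "measured", "known", "first", "only" and "open" are said of these compounds alone.

Compound 1 `ClCc1cccc(Cn2cnc3ncnc(Cl)c32)c1` gives 32400 nM in a functional assay on SW-620 cells (Homo sapiens) for cytotoxicity, read by sulforhodamine B assay, with a stated time of 48 h; on this read-out higher numbers stand for weaker inhibition of growth and lower numbers for stronger inhibition of growth. Compound 2 `ClCc1ccccc1Cn1cnc2ncnc(Cl)c21` shares its atoms but joins them differently; the difference between the two cores is not broken down here. In this assay compound 2 gives 4670 nM, a lower number than compound 1. Compound 3 `ClCc1cccc(Cn2cnc3nc(Cl)nc(Cl)c32)c1` carries one change against compound 1, (chloro in place of hydrogen on an aromatic carbon), and in this assay compound 3 gives 1650 nM. Going by the values given here, the step of a 20-fold lower number from compound 1 to compound 3 (1.29 log units; beyond the scatter) is the only measured instance of this change.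

Compound 4 `ClCc1ccccc1Cn1cnc2nc(Cl)nc(Cl)c21`, not yet measured, is built from compound 2 by the same change, (chloro in place of hydrogen on an aromatic carbon), at a place described in the same words. The expectation for compound 4 rests on a single step, so it is taken somewhat smaller than the measured one; the estimated step is a 12-fold lower number from compound 2 to compound 4 (1.07 log units; beyond the scatter) in this assay. For compound 4 the expected value in this assay is 400 nM, with a likely range from 100 nM to 1600 nM.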

Compound 4, concentration for total growth inhibition: 670 nM
Beside the measured number, compound 4's estimate is 1.7-fold (0.22 log units) below it, and the stated range covers the measured number.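

In this assay the change gives a 7.0-fold lower number from compound 2 to compound 4 (0.84 log units; beyond the scatter) on the second core, so a lower number with chloro in place of hydrogen holds on both cores shown. The size of the step does not carry over unchanged from one core to the other: the same change on two cores in this assay, a 20-fold lower number (1.29 log units; beyond the scatter) from compound 1 to compound 3 and a 7.0-fold lower number (0.84 log units; beyond the scatter) from compound 2 to compound 4, 2.8-fold (0.45 log units) apart, beyond the scatter of two such steps. The two steps support only the direction on these two cores; they give no rule for the size on a further core and no reason for the gap.

Still open, from the compounds shown here alone, is whether other groups on this aromatic carbon between two ring nitrogen atoms, such as an amine, a methoxy group or a fluoro group, would lower the number as chloro does. Also open, going by these compounds, is whether the step would keep its direction if the chloromethyl group gave way to a hydroxymethyl group or a longer chain.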